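The source may report more compounds than this note shows. Statements on the series, on what has been measured and on what is new or still open speak of the compounds shown alone.

Working notes on the series. In a functional assay on GBM3 cells (Homo sapiens) for antiproliferative activity, read by WST assay, with a stated time of 72 h (on this read-out higher numbers stand for weaker inhibition and lower numbers for stronger inhibition), compound 1 (`O=C(Nc1cccc(F)c1)Nc1cc2ncncc2cc1OCc1cccc(Cl)c1`) gives 8300 nM and compound 2 (`O=C(Nc1ccccc1F)Nc1cc2ncncc2cc1OCc1ccccc1F`) gives 3800 nM. Compound 2 therefore holds the lower of the two numbers, and its gap to compound 1 lies beyond the scatter. For the measured compounds named here, these two compounds differ in more than one place, so no measured step isolates a single change.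

The next compound is compound 3 (`O=C(Nc1ccccc1F)Nc1cc2ncncc2cc1OCc1cccc(Cl)c1`), still to be measured in this assay. It keeps the core and the urea side of compound 2, and the change is 3-chlorophenyl in place of 2-fluorophenyl on a saturated chain carbon bound to an oxygen on an aromatic ring. In other words, 2-fluorobenzyl gives way to 3-chlorobenzyl. Going by the values given here, the same 3-chlorobenzyl group occurs in compound 1, which stands at 8300 nM, and this is the only guide to the direction, a weak one since that compound differs from compound 3 elsewhere.

A small move toward weaker inhibition is expected, possibly not beyond the scatter. The expected step is a 1.4-fold higher number from compound 2 to compound 3 (0.16 log units; within the scatter). For compound 3 the estimated value is 5500 nM, with an expected range of 2200 nM to 13000 nM.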

Compound 3, half-maximal inhibitory concentration: 7500 nM
Beside the measured number, compound 3's estimate is 1.4-fold (0.13 log units) below it, within the range that was stated.
By their numbers in this assay, from the lowest: compounds 2, 3 and 1 (each within the scatter of the next, the first and the last beyond it).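

Read alone for the first time, the exchange of 2-fluorobenzyl for 3-chlorobenzyl in this assay gives a 2.0-fold higher number from compound 2 to compound 3 (0.30 log units; within the scatter) and so does not separate the two groups at this position on this read-out. With 3-chlorobenzyl held fixed, 2-fluorophenyl in place of 3-fluorophenyl on an amide-type nitrogen gives a 1.1-fold lower number from compound 1 to compound 3 (0.04 log units; within the scatter) and likewise does not separate the two groups, so neither single change shown here stands clear of the scatter. No measurement at hand speaks to the reason for either step.

The compounds shown carry only a fluorine or a chlorine on the benzyl ring and only a fluorine on the phenyl ring of the urea, so it remains open whether plain benzyl, a longer chain such as phenethyl or a chain ending in an amine would move the number at this position. Going by these compounds, it is also open how 2-fluorobenzyl reads alongside 3-fluorophenyl on the urea, a pairing that would show whether the two changes add up or depend on each other.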